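From pyridin-3-yl to furan-2-yl on a shared core

The source may hold more compounds than are shown below. What is called first, only, known or untested is meant among the compounds shown, and "the series" means these compounds.

In a functional assay on A-375 cells (Homo sapiens) for activation, with a stated time of 3 days (on this read-out higher numbers stand for an effect only at larger amounts of compound and lower numbers for an effect already at smaller amounts), compound 1 (`O=C(Nc1ccc(-c2cscn2)cc1)C1CCCN(Cc2cccc(F)c2)C1`) gives 5000 nM and compound 2 (`O=C(Nc1ccc(-c2cscn2)cc1)C1CCCN(Cc2cc(F)cc(F)c2)C1`) gives 1500 nM. Compound 3 (`O=C(Nc1ccc(-c2cccnc2)cc1)C1CCCN(Cc2ccc(F)c(F)c2)C1`) gives 1060 nM. That number lies within the scatter of compound 2 and is clearly lower than the number for compound 1, so compound 3 sits at the low end of this small set, level with compound 2.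

Compound 4 (`O=C(Nc1ccc(-c2ccco2)cc1)C1CCCN(Cc2ccc(F)c(F)c2)C1`) keeps the rest of compound 3 and changes one group: furan-2-yl in place of pyridin-3-yl on an aromatic carbon, para to a large group (furan-2-yl in place of pyridin-3-yl on an aromatic carbon).

Within the data shown here, only one measured step changes a single place, and it is a modest one: a 3.3-fold lower number from compound 1 to compound 2 (0.52 log units; beyond the scatter). It comes from fluoro in place of hydrogen, not from this swap, so it offers only a rough sense of how far one small change can move the number. Compound 3 differs from compound 2 in more than one place, so that pair isolates nothing either. With no direct evidence, the expected change is a 1.1-fold higher number from compound 3 to compound 4 (0.05 log units; within the scatter), which would stay within the scatter, in no firm direction. For compound 4 the estimated value is 1200 nM, with an expected range from 400 nM to 3500 nM.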

Compound 4, half-maximal effective concentration: 2200 nM
Estimate against measurement, compound 4: 1.8-fold (0.26 log units) below; measured number inside the range.
By their numbers in this assay, from the lowest: compounds 3, 2 and 4 (each within the scatter of the next, the first and the last beyond it); then compound 1.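

In this assay, among these compounds, the step from pyridin-3-yl to furan-2-yl is the first change at this position that can be read on its own: a 2.1-fold higher number from compound 3 to compound 4 (0.32 log units; beyond the scatter). It shows that this aromatic carbon, para to a large group, is not indifferent to which ring it carries: with the rest of the molecule held fixed, a five-membered ring containing oxygen in place of a six-membered ring containing nitrogen calls for more compound to reach the same effect, by a modest amount. The two groups have the same counts of hydrogen-bond donors and acceptors and no net charge, and no measurement at hand explains the shift.

Among the compounds shown here, only one pair isolates this swap, so it remains open whether the step would keep its size and direction with a different fluorine pattern on the other end of the molecule. Also open, going by these compounds, is how the number would respond if a group of a different kind stood at this position, such as a carboxylic acid, an amine or a plain phenyl ring.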